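The compounds below may be only part of what the source reports. "The series", "measured", "known", "first", "only" and "open" are said of these compounds alone.

In a functional assay on SW480 cells (Homo sapiens) for antiproliferative activity, read by MTT assay, with a stated time of 48 h (a higher number here means a weaker inhibitor, a lower number a stronger inhibitor), compound 2 `CCCCCCCCC(CCO)n1cnc2c(N)ncnc21` gives 20700 nM. This places it level with compound 3 `CCCCCCCCC(CCO)n1cnc2c(N)nc(Cl)nc21`, which gives 13100 nM, the step being a 1.6-fold lower number from compound 2 to compound 3 (0.20 log units; within the scatter). Compound 1 `CCCCCCCCC(CCO)n1cnc2c(Cl)ncnc21` gives 1370 nM, a much lower number, the step being a 15-fold higher number from compound 1 to compound 2 (1.18 log units; beyond the scatter). The change to compound 4 `CCCCCCCCCCC(CCO)n1cnc2c(N)ncnc21` is ethyl in place of hydrogen on a saturated chain carbon, nine bonds along the chain from an aromatic nitrogen, ethyl in place of hydrogen on a saturated chain carbon. Both measured steps fall on an aromatic carbon and neither touches the chain, so neither gives a size for this change. No step beyond the scatter is therefore expected in this assay, and the expectation stays near compound 2 at 20700 nM. The expected step is a 1.4-fold lower number from compound 2 to compound 4 (0.14 log units; within the scatter). Compound 4 is estimated at 15000 nM, with an expected range of 5000 nM to 35000 nM.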

Compound 4, half-maximal inhibitory concentration: 1200 nM
For compound 4 the middle estimate is 13-fold (1.10 log units) above the measured one; measured number below the stated range.
By their numbers in this assay, from the lowest: compounds 4 and 1 (each within the scatter of the next); then compounds 3 and 2 (each within the scatter of the next).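

In this assay the chain proves to be a place where a small addition counts: ethyl in place of hydrogen on a saturated chain carbon, nine bonds along the chain from an aromatic nitrogen, gives a 17-fold lower number from compound 2 to compound 4 (1.24 log units; beyond the scatter) and so a large step. Going by these compounds alone, the earlier steps all fell on an aromatic carbon, so this is the first to show the number moving beyond the scatter with the core unchanged. Nothing available explains this step. As far as these compounds go, whether a longer chain lowers the number further, or a chain ending in an amine or a carboxylic acid keeps the step, stays open. So does whether ethyl gives a step of this size on compound 1, which carries chloro in place of amino.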